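The compounds below may be only part of what the source reports. "The series", "measured", "known", "first", "only" and "open" are said of these compounds alone.

In a toxicity assay on HepG2 2.2.15 cells (Homo sapiens) for cytotoxicity, read by CCK-8 assay, with a stated time of 8 days (on this read-out lower numbers stand for higher toxicity in this test and higher numbers for lower toxicity in this test), compound 1 `CC(C)Cc1nn(-c2nccs2)cc1C(=O)NCc1ccc(C(F)(F)F)cc1` reaches only the limit > 100000 nM, not a number. Compound 2 `COc1ccc(CNC(=O)c2cn(-c3nccs3)nc2CC(C)C)cc1` likewise gives only the limit > 100000 nM. Compound 3 `CC(C)Cc1nn(-c2nccs2)cc1C(=O)NCc1ccccc1F` also stops at the limit > 100000 nM, which is where it stands on everything measured so far. Hence the changes a step that the two limits leave unreadable from compound 1 to compound 2 and a step that the two limits leave unreadable from compound 2 to compound 3 cannot be sized, because of the limit of > 100000 nM in this assay, at which 3 of the 3 values shown sit. Compound 4 `CC(C)Cc1nn(-c2nccs2)cc1C(=O)NCc1ccc(N)cc1` differs from compound 3 by 4-aminophenyl in place of 2-fluorophenyl on a saturated chain carbon bound to an amide-type nitrogen. Neither measured step is readable for this change, so no step beyond the scatter is anticipated in this assay, and compound 4 is expected to rest again at that limit, with the estimated a number no higher from compound 3 to compound 4 (the limit leaves the size open). The estimated value for compound 4 is 100000 nM, ranging from 50000 nM to 300000 nM.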

Compound 4, half-maximal cytotoxic concentration: > 100000 nM
Compound 4 was reported as a limit; the forecaster's own chance of this, stated with the estimate: 85%; the middle value lies on the limit itself.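

In this assay compound 4 gives the limit > 100000 nM and no number. Its steps from compound 1, compound 2 and compound 3 therefore cannot be read: the limit of > 100000 nM in this assay, at which 4 of the 4 values shown sit.
The compounds shown leave open whether any change to the shared core would give a measurable number in this test.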